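The compounds below may be only part of what the source reports. "The series", "measured", "known", "first", "only" and "open" are said of these compounds alone.

Measured compounds:
- Compound 1, `CC(C)/C(=C1\C(=O)NC(=O)N1C)c1ccc(-c2ccc3cccc(F)c3c2)[nH]c1=O`, gives 22500 nM in a physicochemical assay for solubility, in phosphate buffer, measured as kinetic solubility; a lower number here means a less soluble compound, a higher number a more soluble compound.
- Compound 2, `O=C1NC(=O)/C(=C/C(c2ccc(-c3ccc4cccc(F)c4c3)[nH]c2=O)C2CC2)O1`, gives 30800 nM in this assay.
- Compound 3, `CC(C)[C@@H](c1ccc(-c2ccc3cccc(F)c3c2)[nH]c1=O)[C@H]1OC(=O)NC1=O`, gives 31600 nM in this assay.

The three measured compounds share the same core and differ in the group carried on the chain that links the core to the five-membered ring. On solubility, compound 2 sits within the usual scatter of both compound 1 and compound 3, so the three numbers cannot be told apart with confidence; none of them stands out as clearly more or less soluble.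

Compound 4, `O=C1NC(=O)/C(=C/C(Cc2ccccc2)c2ccc(-c3ccc4cccc(F)c4c3)[nH]c2=O)O1`, has not yet been measured. It differs from compound 2 in one place: benzyl in place of cyclopropyl on a saturated chain carbon bound to an aromatic carbon and a double-bonded chain carbon. For the measured compounds named here, no measured pair in this set shows a change of this kind, so the size of the step has to be guessed. The expectation is a moderate drop in solubility from compound 2 to compound 4, larger than the scatter but not dramatic, so that the step of a 2.6-fold lower number from compound 2 to compound 4 (0.41 log units; beyond the scatter) is expected. Compound 4 is therefore estimated at 12000 nM, with a range from 4000 nM to 32000 nM.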

Compound 4, solubility: 9100 nM
Beside the measured number, compound 4's estimate is 1.3-fold (0.12 log units) above it; measured number inside the range.
By their numbers in this assay, from the lowest: compound 4; then compounds 1, 2 and 3 (each within the scatter of the next).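

For the compounds shown here, this is the first step read at this position: in this assay, benzyl in place of cyclopropyl on a saturated chain carbon bound to an aromatic carbon and a double-bonded chain carbon gives a 3.4-fold lower number from compound 2 to compound 4 (0.53 log units; beyond the scatter). The group carried here can therefore move the read-out, and this swap of one carbon-only group for another, with no hydrogen-bond donors or acceptors on either side, is enough to do so. Nothing measured on these compounds accounts for the size or direction of this step.

With only this one swap, the compounds shown cannot separate the larger carbon count of benzyl from its aromatic ring. From the compounds shown here alone, whether an amine or a carboxylic acid on this same chain carbon would raise the number above that of compound 2 remains open.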